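Triazole series: 2,5-dimethoxyphenyl in place of 2,5-dihydroxyphenyl

The source may hold more compounds than are shown below. What is called first, only, known or untested is meant among the compounds shown, and "the series" means these compounds.

Measured so far:
compound 1 `COc1ccc(OC)c(-c2cn(-c3ccc(O)c(C(=O)Nc4cccc(C(F)(F)F)c4)c3)nn2)c1`: 46%
compound 2 `O=C(OCCCc1ccccc1)c1cc(-n2cc(-c3cc(O)ccc3O)nn2)ccc1O`: 39%

In a functional assay on HCT-116 cells (Homo sapiens) for inhibition, read by MTT assay, with a stated time of 2 days, tested at 10 uM (on this read-out lower numbers stand for less inhibition and higher numbers for more inhibition at the one concentration tested (going by the name of the read-out)), compound 1 gives 46% and compound 2 gives 39%. Compound 2 stands lowest of the two numbers, its gap to compound 1 lying within the scatter. Compound 3 `COc1ccc(OC)c(-c2cn(-c3ccc(O)c(C(=O)OCCCc4ccccc4)c3)nn2)c1` differs from compound 2 by 2,5-dimethoxyphenyl in place of 2,5-dihydroxyphenyl on an aromatic carbon. Compound 1 already carries the 2,5-dimethoxyphenyl on an aromatic carbon of the shared core and sits within the scatter of compound 2. The expected step is therefore a number 5 percentage points higher from compound 2 to compound 3 (within the scatter), none beyond the scatter. Compound 3 is estimated at 44%, with a range from 30% to 58%.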

Compound 3, a percentage reported as inhibition, at one concentration (the size of the read-out at that concentration, not a potency): 13%
The estimate for compound 3 lay 31 percentage points above the measured number, outside the stated range (below it).
By their numbers in this assay, from the lowest: compound 3; then compounds 2 and 1 (each within the scatter of the next).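

In this assay 2,5-dimethoxyphenyl in place of 2,5-dihydroxyphenyl on the five-membered aromatic ring with 3 nitrogen gives a number 26 percentage points lower from compound 2 to compound 3 (beyond the scatter) and so costs inhibition at this position when the carbonyl carbon bears 3-phenylpropoxy. With 2,5-dimethoxyphenyl held constant, 3-phenylpropoxy in place of (3-(trifluoromethyl)phenyl)amino gives a number 33 percentage points lower from compound 1 to compound 3 (beyond the scatter) and so shows that the carbonyl substituent matters too. No measurement at hand accounts for either step.

Open, from the compounds shown here alone, is whether a phenyl carrying one hydroxy and one methoxy group, or an aminophenyl, would behave like 2,5-dihydroxyphenyl at this position.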